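The source may hold more compounds than are shown below. What is called first, only, known or untested is meant among the compounds shown, and "the series" means these compounds.

Going by the values given here, in a functional assay on SMMC-7721 cells (Homo sapiens) for antiproliferative activity, read by MTT assay, with a stated time of 48 h (on this read-out lower numbers stand for stronger inhibition and higher numbers for weaker inhibition), compound 3 `CC(C)=CCC[C@]1(C)/C=C/[C@@H](OC(=O)C=C(C)C)[C@](C)(O)/C=C/C(=O)/C(CN2CCCC2)=C\C1` gives 140 nM and holds the lowest of the three values so far. Compound 1 `CC(=O)O[C@]1(C)/C=C/C(=O)/C(CO)=C\C[C@](C)(CCC=C(C)C)/C=C/[C@H]1OC(=O)C=C(C)C` gives 3080 nM in the same read-out, and compound 2 `CO[C@]1(C)/C=C/C(=O)/C(CO)=C\C[C@](C)(CCC=C(C)C)/C=C/[C@H]1OC(=O)C=C(C)C` gives 15800 nM there. Compound 4 `CSC(=S)OC/C1=C/C[C@](C)(CCC=C(C)C)/C=C/[C@@H](OC(=O)C=C(C)C)[C@](C)(O)/C=C/C1=O` is reached from compound 3 by one change: a group of 5 heavy atoms (2 carbon, 1 oxygen, 2 sulfur; no ring) in place of a group of 5 heavy atoms (4 carbon, 1 nitrogen; one five-membered non-aromatic ring with 1 hetero atom), on a saturated chain carbon bound to a double-bonded ring carbon in the pyrrolidin-1-yl position. Among the compounds with values here, the only measured step, a 5.1-fold higher number from compound 1 to compound 2 (0.71 log units; beyond the scatter) for methyl in place of acetyl on an oxygen on a saturated carbon, lies beyond the scatter. It sits at another place, however, and offers only a rough size for a single change in this series. Compounds 1 and 2 lack the pyrrolidin-1-yl group and also differ from compound 3 elsewhere, so no measurement isolates this exchange. A rise of similar size is therefore expected in this assay on losing the group, with wide uncertainty. The expected step is a 7.1-fold higher number from compound 3 to compound 4 (0.85 log units; beyond the scatter) by estimate. Compound 4 is estimated at 1000 nM within a range of 200 nM to 5000 nM in this read-out.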

Compound 4, half-maximal inhibitory concentration: 720 nM
The estimate for compound 4 lay 1.4-fold (0.14 log units) above the measured number, within the range that was stated.
By their numbers in this assay, from the lowest: compound 3; then compound 4; then compound 1; then compound 2.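

In this assay, going by these compounds alone, exchanging pyrrolidin-1-yl for the group of 5 heavy atoms (2 carbon, 1 oxygen, 2 sulfur; no ring) gives a 5.1-fold higher number from compound 3 to compound 4 (0.71 log units; beyond the scatter), the first direct reading at this saturated chain carbon bound to a double-bonded ring carbon. The value therefore depends on the group carried at this place, although the step is modest and compound 4, with neither ring nor nitrogen in that group, still gives 720 nM. No evidence on the cause of this step is at hand.

The pair does not separate the loss of the nitrogen from the loss of the ring or the entry of the sulfur atoms. Going by these compounds, whether the lower number of compound 3 extends to other amines remains open, and a piperidin-1-yl or an open-chain dimethylamino group on the same carbon would bear on this.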